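Aryl amide variation on a shared cyclopropane dicarboxamide core

The compounds below may be only part of what the source reports. "The series", "measured", "known", "first", "only" and "open" are said of these compounds alone.

Compound 2, `COc1cccc(NC(=O)C2(C(=O)Nc3ccc(Nc4ncc5cc(C(=O)N(C)C)n(C6CCCC6)c5n4)cc3)CC2)c1`, sits at the top of the two numbers gathered so far in a functional assay on A549 cells (Homo sapiens) for inhibition, read by CCK-8 assay, with a stated time of 72 h, tested at 10 uM (a lower number here means less inhibition of growth, a higher number more inhibition of growth at the concentration tested), where compound 2 gives 96%. Its nearest neighbour is compound 1, `CN(C)C(=O)c1cc2cnc(Nc3ccc(NC(=O)C4(C(=O)Nc5ccccc5F)CC4)cc3)nc2n1C1CCCC1`, which in this assay gives 88.6%; the step of a number 7.4 percentage points higher from compound 1 to compound 2 (within the scatter) lies within the usual scatter, so the two values cannot be ordered. Compound 3, `CN(C)C(=O)c1cc2cnc(Nc3ccc(NC(=O)C4(C(=O)Nc5ccc(C(F)(F)F)cc5)CC4)cc3)nc2n1C1CCCC1`, has not yet been measured. It differs from compound 2 by 4-(trifluoromethyl)phenyl in place of 3-methoxyphenyl on an amide-type nitrogen. Among the measured compounds shown here, the only measured step that bears on this change is the earlier swap of aryl groups on the same amide-type nitrogen, a number 7.4 percentage points higher from compound 1 to compound 2 (within the scatter), which stayed inside the scatter. On that basis no step beyond the scatter is expected for compound 3 in this assay, with an estimated a number 6 percentage points lower from compound 2 to compound 3 (within the scatter). Compound 3 is therefore estimated at 90%, within a range from 75% to 99%.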

Compound 3, percent growth inhibition at one concentration: 87.9%
The estimate for compound 3 lay 2.1 percentage points above the measured number, and the stated range covers the measured number.
By their numbers in this assay, from the lowest: compounds 3, 1 and 2 (each within the scatter of the next).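

In this assay the 4-(trifluoromethyl)phenyl group on the amide-type nitrogen gives a number 8.1 percentage points lower from compound 2 to compound 3 (within the scatter) and a number 0.7 percentage points lower from compound 1 to compound 3 (within the scatter) so neither swap moves the read-out outside the scatter. Three aryl groups, 2-fluorophenyl, 3-methoxyphenyl and 4-(trifluoromethyl)phenyl, now sit at this position with values that cannot be ordered, and this holds even for the change from 8 heavy atoms with 1 hydrogen-bond acceptor to 10 heavy atoms with 0 hydrogen-bond acceptors. No measurement at hand accounts for this flat result.

Going by these compounds, what a carboxylic acid or a dimethylamino chain on the aryl ring, or a morpholine in place of that ring, would do at this nitrogen stays open. A single tested concentration also leaves open whether these three compounds would separate at lower concentrations.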